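The source may hold more compounds than are shown below. What is called first, only, known or untested is meant among the compounds shown, and "the series" means these compounds.

Measured so far in a functional assay on HCT-116 cells (Homo sapiens) for cytotoxicity, read by sulforhodamine B assay, with a stated time of 24 h; on this read-out lower numbers stand for stronger inhibition and higher numbers for weaker inhibition:
- compound 1 `N#CCC(=O)N/N=C1\C(=O)Nc2ccc(S(=O)(=O)N3CCOCC3)cc21`: 10300 nM
- compound 2 `O=C1Nc2ccc(S(=O)(=O)N3CCOCC3)cc2/C1=N/c1cccc(C(F)(F)F)c1`: 15900 nM
- compound 3 `Cc1ccc(S(=O)(=O)N/N=C2\C(=O)Nc3ccc(S(=O)(=O)N4CCOCC4)cc32)cc1`: 23400 nM

Compound 3 cannot be told apart from compound 2 within the scatter, and only its gap to compound 1 goes beyond it. Compound 4 `CC(=O)N/N=C1\C(=O)Nc2ccc(S(=O)(=O)N3CCOCC3)cc21` is not yet measured. It differs from compound 3 in one place: acetyl in place of (4-methylphenyl)sulfonyl on an amine nitrogen.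

The closest evidence comes from the same nitrogen: a 2.3-fold higher number from compound 1 to compound 3 (0.36 log units; beyond the scatter) (modest). For the measured compounds named here, compound 4 reverses that change in kind, although no measured compound carries acetyl itself. The other step, a 1.5-fold higher number from compound 1 to compound 2 (0.19 log units; within the scatter), stays within the scatter and replaces the whole group on the double-bonded nitrogen, so it adds little.

A modest move to a lower number is therefore expected in this assay, near the edge of the scatter. The expected step is a 2.0-fold lower number from compound 3 to compound 4 (0.29 log units; within the scatter) (an estimate). The estimated value for compound 4 is 12000 nM, with an expected range from 6000 nM to 25000 nM (an estimate).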

Compound 4, half-maximal inhibitory concentration: 29000 nM
Beside the measured number, compound 4's estimate is 2.4-fold (0.38 log units) below it; measured number above the stated range.
By their numbers in this assay, from the lowest: compounds 1, 2, 3 and 4 (each within the scatter of the next, the first and the last beyond it).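

In this assay, acetyl in place of (4-methylphenyl)sulfonyl on the amine nitrogen gives a 1.2-fold higher number from compound 3 to compound 4 (0.09 log units; within the scatter), so this position shows no separation between these two groups, despite the ring lost with the sulfonyl group. On the saturated chain carbon bound to a carbonyl carbon, hydrogen in place of cyano gives a 2.8-fold higher number from compound 1 to compound 4 (0.45 log units; beyond the scatter) and goes beyond the scatter, while acetamido in place of 3-(trifluoromethyl)phenyl on the double-bonded nitrogen gives a 1.8-fold higher number from compound 2 to compound 4 (0.26 log units; within the scatter) and stays within it. No measurement shown here accounts for any of these steps.

Still open, from the compounds shown here alone, is whether a longer chain or an amine in place of the cyano would hold the number of compound 1 in this assay. Also open, going by these compounds, is whether a benzoyl group on the amine nitrogen would read like acetyl.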